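Chloro for Hydrogen Repeated on a Second Core

The source may report more compounds than this note shows. Statements on the series, on what has been measured and on what is new or still open speak of the compounds shown alone.

Compound 1 `COc1cc(N(C)CCN(C)C)c(NC(=O)c2ccncc2)cc1Nc1nccc(-c2cn(C)c3ccccc23)n1` gives 6860 nM in a functional assay on NCI-H1975 cells (Homo sapiens) for antiproliferative activity, read by MTT assay, with a stated time of 72 h; on this read-out lower numbers stand for stronger inhibition and higher numbers for weaker inhibition. Compound 2 `COc1cc(N(C)CCN(C)C)c(NC(=O)c2ccnc(Cl)c2)cc1Nc1nccc(-c2cn(C)c3ccccc23)n1` differs from compound 1 by chloro in place of hydrogen on an aromatic carbon and in this assay compound 2 gives 2050 nM, a step of a 3.3-fold lower number from compound 1 to compound 2 (0.52 log units; beyond the scatter). Compound 3 `COc1cc(N(C)C)c(NC(=O)c2ccncc2)cc1Nc1nccc(-c2cn(C)c3ccccc23)n1` differs from compound 1 by hydrogen in place of (dimethylamino)methyl on a saturated chain carbon bound to a nitrogen on an aromatic ring, and in this assay compound 3 gives 1470 nM, a step of a 4.7-fold lower number from compound 1 to compound 3 (0.67 log units; beyond the scatter). The values of compound 3 and compound 2 lie within the scatter of each other. Compound 4 `COc1cc(N(C)C)c(NC(=O)c2ccnc(Cl)c2)cc1Nc1nccc(-c2cn(C)c3ccccc23)n1` differs from compound 3 by chloro in place of hydrogen on an aromatic carbon, the same change that turned compound 1 into compound 2, here set on the core of compound 3. Because a 3.3-fold lower number from compound 1 to compound 2 (0.52 log units; beyond the scatter) lay beyond the scatter, a step of similar size is expected, a 2.9-fold lower number from compound 3 to compound 4 (0.47 log units; beyond the scatter). Compound 4 is therefore estimated at 500 nM in this assay, with a plausible range from 200 nM to 1300 nM.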

Compound 4, half-maximal inhibitory concentration: 9200 nM
The estimate for compound 4 lay 18-fold (1.26 log units) below the measured number; the measured number lies above the stated range.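

In this assay, chloro in place of hydrogen did not carry over from one core to the other, since on the core of compound 3 it gave a 6.3-fold higher number from compound 3 to compound 4 (0.80 log units; beyond the scatter), opposite in direction to the earlier step: the same change on two cores in this assay, a 3.3-fold lower number (0.52 log units; beyond the scatter) from compound 1 to compound 2 and a 6.3-fold higher number (0.80 log units; beyond the scatter) from compound 3 to compound 4, 21-fold (1.32 log units) apart, beyond the scatter of two such steps. Hydrogen in place of (dimethylamino)methyl likewise changed direction once chloro was present, giving a 4.5-fold higher number from compound 2 to compound 4 (0.65 log units; beyond the scatter): the same change on two cores in this assay, a 4.7-fold lower number (0.67 log units; beyond the scatter) from compound 1 to compound 3 and a 4.5-fold higher number (0.65 log units; beyond the scatter) from compound 2 to compound 4, 21-fold (1.32 log units) apart, beyond the scatter of two such steps. The two changes therefore do not add up across these four compounds, but this single set does not show why the direction reverses, nor how either change would behave on any other core.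

The compounds shown leave open whether fluoro or methyl in place of chloro would behave as chloro does on each core. They also leave open how a longer aminoalkyl chain would affect the outcome.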